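Removing the allyl group from compound 1

The compounds below may be only part of what the source reports. "The series", "measured", "known", "first", "only" and "open" are said of these compounds alone.

In a functional assay on NCI-H1581 cells (Homo sapiens) for antiproliferative activity, read by CCK-8 assay, with a stated time of 72 h (on this read-out lower numbers stand for stronger inhibition and higher numbers for weaker inhibition), compound 1 `C=CCN1CCN(c2ccc(C(=O)Nc3n[nH]c4nc(-c5c(Cl)c(OC)cc(OC)c5Cl)ccc34)cc2)CC1` gives 3.3 nM, the lowest of the three numbers in hand. Compound 2 `COc1cc(OC)c(Cl)c(-c2ccc3c(NC(=O)c4ccc(N5CCN(C)CC5)cc4Cl)n[nH]c3n2)c1Cl` gives 27.6 nM and compound 3 `COc1cc(N2CCN(C)CC2)ccc1C(=O)Nc1n[nH]c2nc(-c3c(Cl)c(OC)cc(OC)c3Cl)ccc12` gives 525 nM, both higher than the value of compound 1 by more than the scatter. Compound 4 `COc1cc(OC)c(Cl)c(-c2ccc3c(NC(=O)c4ccc(N5CCNCC5)cc4)n[nH]c3n2)c1Cl` has not yet been measured. It differs from compound 1 by a single change, hydrogen in place of allyl on an amine nitrogen in a ring, so that 4-allylpiperazin-1-yl becomes piperazin-1-yl.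

For the measured compounds named here, only one measured step is available, a 19-fold higher number from compound 2 to compound 3 (1.28 log units; beyond the scatter), with methoxy in place of chloro on an aromatic carbon. Going by the values given here, it lies elsewhere in the molecule, so it shows only that a single change can move these numbers far. Among the compounds with values here, no measured step involves the allyl group, and the expectation is therefore uncertain. The expected outcome is a 1.8-fold higher number from compound 1 to compound 4 (0.26 log units; within the scatter), with no shift beyond the scatter anticipated in this assay. For compound 4 the estimated value is 6 nM, with an expected range of 1.5 nM to 30 nM.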

Compound 4, half-maximal inhibitory concentration: 1.4 nM
Estimate against measurement, compound 4: 4.3-fold (0.63 log units) above; the whole stated range lies above it.
By their numbers in this assay, from the lowest: compound 4; then compound 1; then compound 2; then compound 3.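

The allyl group on the amine nitrogen in the ring is not needed for activity in this assay: replacing it with hydrogen gives a 2.4-fold lower number from compound 1 to compound 4 (0.37 log units; beyond the scatter). For the compounds shown here, this is the first measured step at this position, and it shows that 4-allylpiperazin-1-yl can become piperazin-1-yl with a modest gain rather than a loss. The compounds shown offer no evidence that accounts for this gain.

The compounds shown leave open whether the gain belongs to the free ring nitrogen or simply to the loss of the allyl group, since a propyl chain, which would keep the carbons without the double bond, does not appear among them. They also leave open how an acetyl or a hydroxyethyl group on the same nitrogen would compare with hydrogen in this assay.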